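Bromination of the hydroxyphenyl ring in a hydrazone series

A few compounds are considered here, and "the series" means these few. Any claim that something is new, unique, unknown or untested is made for them only; others in the source may bear on it.

Measured so far:
compound 1 `Cc1c(C(=O)N/N=C\c2ccccc2O)oc2cccc(O)c12`: 8350 nM
compound 2 `Cc1c(C(=O)N/N=C\c2c(O)cccc2F)oc2cccc(O)c12`: 8050 nM
compound 3 `Cc1c(C(=O)N/N=C\c2ccncc2)oc2cccc(O)c12`: >= 40000 nM

Compound 1 is one of two compounds with a numerical value in a functional assay on PC-3 cells (Homo sapiens) for inhibition (on this read-out lower numbers stand for stronger inhibition and higher numbers for weaker inhibition), and its neighbour compound 2 sits within the scatter of it: a 1.0-fold lower number from compound 1 to compound 2 (0.02 log units; within the scatter). Compound 3 gives only a limit in this assay, (the limit of >= 40000 nM in this assay, at which 1 of the 3 values shown sits), so the step of an at least 4.7-fold higher number from compound 1 to compound 3 (0.68 log units; beyond the scatter) is known only as a lower bound on its size.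

Compound 4 `Cc1c(C(=O)N/N=C\c2ccc(Br)cc2O)oc2cccc(O)c12` differs from compound 1 by a single change: bromo in place of hydrogen on an aromatic carbon. Among the measured compounds shown here, no measured pair shows this exact change. The nearest comparison is the substitution of a hydrogen on the same ring in compound 2, a step that stayed within the scatter: a 1.0-fold lower number from compound 1 to compound 2 (0.02 log units; within the scatter). The replacement of the whole ring in compound 3 is a different kind of change and does not bear directly on a substituent swap. Compound 4 is therefore expected to land close to compound 1, with the step of a 1.2-fold lower number from compound 1 to compound 4 (0.08 log units; within the scatter) reflecting that. The expected value of compound 4 is 7000 nM, within a range from 2500 nM to 20000 nM.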

Compound 4, half-maximal inhibitory concentration: 2050 nM
Estimate against measurement, compound 4: 3.4-fold (0.53 log units) above; measured number outside the range, below it.
By their numbers in this assay, from the lowest: compound 4; then compounds 2 and 1 (each within the scatter of the next). At a limit, above all of these: compound 3.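

On the 2-hydroxyphenyl ring, bromo on the carbon para to a large group and meta to a hydroxy group moves the result in this assay beyond the scatter: a 4.1-fold lower number from compound 1 to compound 4 (0.61 log units; beyond the scatter). This shows that a single added atom on this ring can change the number, which the fluoro of compound 2 had not shown, and the 4-bromo-2-hydroxyphenyl ring also separates from the 2-fluoro-6-hydroxyphenyl ring, with a 3.9-fold lower number from compound 2 to compound 4 (0.59 log units; beyond the scatter), while the step from the pyridin-4-yl ring reads an at least 19-fold lower number from compound 3 to compound 4 (1.29 log units; beyond the scatter). That last step is only a lower bound, and the value of compound 3 is a limit: the limit of >= 40000 nM in this assay, at which 1 of the 4 values shown sits.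

As far as these compounds go, it remains open whether chloro, methoxy or an amine on this same carbon would shift the number as bromo does. Also open, from the compounds shown here alone, is whether the step needs the ring's hydroxy group, which all three compounds with numerical values carry.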